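The source may hold more compounds than are shown below. What is called first, only, known or untested is meant among the compounds shown, and "the series" means these compounds.

Measured so far:
compound 1 `CC(C)c1c(C(=O)NCc2cccc(F)c2F)nn(-c2ccc(F)cc2)c1OC[C@@H](O)C[C@@H](O)CC(=O)O` — 2 nM
compound 2 `CC(C)c1c(C(=O)N2CCCC2c2ccccc2)nn(-c2ccc(F)cc2)c1OC[C@@H](O)C[C@@H](O)CC(=O)O` — 14 nM

In an assay on microsomes from liver for inhibition of 3-hydroxy-3-methylglutaryl-coenzyme A reductase (Rattus norvegicus) (a higher number here means a weaker inhibitor, a lower number a stronger inhibitor), compound 1 gives 2 nM and compound 2 gives 14 nM. Compound 2 holds the highest of the two numbers; compound 1 is nearest, the gap being a 7.0-fold higher number from compound 1 to compound 2 (0.85 log units; beyond the scatter). Compound 3 `Cc1ccccc1CNC(=O)c1nn(-c2ccc(F)cc2)c(OC[C@@H](O)C[C@@H](O)CC(=O)O)c1C(C)C` differs from compound 2 by (2-methylbenzyl)amino in place of 2-phenylpyrrolidin-1-yl on a carbonyl carbon. For the measured compounds named here, the one measured step that bears on this is a 7.0-fold higher number from compound 1 to compound 2 (0.85 log units; beyond the scatter), where a (2,3-difluorobenzyl)amino gave way to the 2-phenylpyrrolidin-1-yl; the present change runs in the opposite direction, back to a benzyl amide. Compound 3 is therefore expected to show a 4.7-fold lower number from compound 2 to compound 3 (0.67 log units; beyond the scatter) in this assay. The estimate for compound 3 is 3 nM, range 1 nM to 10 nM.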

Compound 3, half-maximal inhibitory concentration: 17 nM
Compound 3: the middle estimate sits 5.7-fold (0.75 log units) below what was measured; the whole stated range lies below it.
By their numbers in this assay, from the lowest: compound 1; then compounds 2 and 3 (each within the scatter of the next).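

In this assay, a return to a benzyl amide does not by itself bring the number back to that of compound 1: the (2-methylbenzyl)amino and the 2-phenylpyrrolidin-1-yl on this carbonyl carbon stay within the scatter (a 1.2-fold higher number from compound 2 to compound 3 (0.08 log units; within the scatter)), with or without the amide hydrogen. Within the benzyl amides, 2-methylphenyl in place of 2,3-difluorophenyl is the change that carries a step beyond the scatter (an 8.5-fold higher number from compound 1 to compound 3 (0.93 log units; beyond the scatter)). No measurement at hand accounts for either step.

Open, on these data alone, is whether a 2-fluorophenyl or 2-chlorophenyl group on the same chain carbon would stand with compound 1 or with compound 3.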